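Methylating the phenol of compound 3: inhibition of L02 cells

A few compounds are considered here, and "the series" means these few. Any claim that something is new, unique, unknown or untested is made for them only; others in the source may bear on it.

Three compounds of this series were tested in a functional assay on L02 cells (Homo sapiens) for inhibition, read by MTT assay, with a stated time of 48 h; on this read-out lower numbers stand for stronger inhibition and higher numbers for weaker inhibition. Compound 1 `COc1ccc2c(=O)c(/C=C/C(=O)Nc3cccc(Cl)c3)coc2c1` gives > 200000 nM, a limit of the assay rather than a number. Compound 2 `COc1ccc2c(=O)c(/C=C/C(=O)Nc3ccc(C)cc3)coc2c1` gives > 200000 nM, again a limit. The step that the two limits leave unreadable from compound 1 to compound 2 therefore cannot be read. Compound 3 `Cc1ccc(CNC(=O)/C=C/c2coc3cc(O)ccc3c2=O)cc1` gives > 200000 nM, also a limit. Its standing among the numbers shown is the shared limit of > 200000 nM in this assay, at which 3 of the 3 values shown sit, at which every measured compound sits.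

Compound 4 `COc1ccc2c(=O)c(/C=C/C(=O)NCc3ccc(C)cc3)coc2c1` differs from compound 3 by methyl in place of hydrogen on an oxygen on an aromatic ring. No measured step involves this change, and the only step shown is unreadable, so nothing shown points in either direction. Compound 4 is therefore expected to sit at the limit as well, with an expected step of a number no higher from compound 3 to compound 4 (the limit leaves the size open) of no readable size. The estimate for compound 4 is 200000 nM, ranging from 50000 nM to 600000 nM.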

Compound 4, half-maximal inhibitory concentration: > 200000 nM
Compound 4: no number, only a limit; the forecaster's own chance of this, stated with the estimate: 85%; the middle value lies on the limit itself.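

The steps from compound 1, compound 2 and compound 3 to compound 4 cannot be read, because all four compounds give only a limit: the limit of > 200000 nM in this assay, at which 4 of the 4 values shown sit.

The compounds shown leave open how strongly any of them inhibits in this assay, and whether hydroxy or methoxy makes any difference there.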